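A Longer Chain at the Limit of the Assay

The compounds below may be only part of what the source reports. "The series", "measured", "known", "first", "only" and "open" are said of these compounds alone.

In an ADME assay on RAW264.7 cells (Mus musculus) for cytotoxicity, read by MTT assay (a lower number here means a stronger inhibitor, a higher number a weaker inhibitor), compound 1 (`CCCCCCCCOc1cccc(O)c1C(=O)/C=C/c1ccc(O)cc1`) gives > 30000 nM, which is a limit. Compound 2 (`CCCCCCCCCCCCOc1cccc(O)c1C(=O)/C=C/c1ccc(O)cc1`) gives > 30000 nM, which is also a limit. Compound 2 therefore has no number of its own and stands at the limit of > 30000 nM in this assay, at which 2 of the 2 values shown sit. Compound 3 (`CCCCCCCCCCCCCCOc1cccc(O)c1C(=O)/C=C/c1ccc(O)cc1`) differs from compound 2 by ethyl in place of hydrogen on a saturated chain carbon, ten or more bonds along the chain from an oxygen on an aromatic ring. Going by the values given here, the one measured step that bears on this change, also a lengthening of the chain, is a step that the two limits leave unreadable from compound 1 to compound 2. That step gives no size to carry over, so the expectation rests only on the shared limit in this assay. The expected change is a step that the limit leaves unreadable from compound 2 to compound 3, with no shift anticipated in either direction beyond the scatter. For compound 3 the estimated value is 35000 nM, with an expected range of 15000 nM to 100000 nM, and another report as a limit is the likeliest outcome.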

Compound 3, half-maximal inhibitory concentration: > 30000 nM
Compound 3: only a limit was reported; the forecaster's own chance of this, stated with the estimate: 80%; the middle value is on the limit's open side.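

In this assay compound 3 gives > 30000 nM as a limit. Going by these compounds alone, no step among compound 1, compound 2 and compound 3 can therefore be read. These compounds leave open how far each true value lies past the limit in this assay and whether the longer chains change it at all.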